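Chloro in place of isopropyl on the shared core

A few compounds are considered here, and "the series" means these few. Any claim that something is new, unique, unknown or untested is made for them only; others in the source may bear on it.

In a physicochemical assay for lipophilicity, using the shake flask method (on this read-out lower numbers stand for lower lipophilicity and higher numbers for higher lipophilicity), compound 3 `CC(C)Oc1cc(Oc2ccc(S(C)(=O)=O)cc2)cc(-c2ncc(C(C)C)c(=O)[nH]2)c1` stands at "not determined" (no result reported) with no number to start from. Compound 4 `CC(C)Oc1cc(Oc2ccc(S(C)(=O)=O)cc2)cc(-c2ncc(Cl)c(=O)[nH]2)c1` differs from compound 3 in one place: chloro in place of isopropyl on an aromatic carbon. The change is chloro in place of isopropyl on an aromatic carbon. Compound 1 `CC(C)Oc1cc(Oc2ccc(S(C)(=O)=O)cc2)cc(-c2nccc(=O)[nH]2)c1` reads 2.14 in this assay and compound 2 `Cc1cnc(-c2cc(Oc3ccc(S(C)(=O)=O)cc3)cc(OC(C)C)c2)[nH]c1=O` reads 2.68 there. Methyl in place of hydrogen on an aromatic carbon gave a number 0.54 log units higher from compound 1 to compound 2 (beyond the scatter) and this is the only guide. Among the measured compounds shown here, no measured step involves chloro or isopropyl. For the measured compounds named here, no step from compound 3 can be expected in numbers, but relative to compound 1 a modest rise is expected, in line with compound 2 at 2.68 in that comparison. For compound 4 the expected value is 2.6 within an estimated range of 2.2 to 3 on this scale.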

Compound 4, distribution coefficient: 2.04
The estimate for compound 4 lay 0.56 log units above the measured number, and the stated range ends above it.
By their numbers in this assay, from the lowest: compounds 4 and 1 (each within the scatter of the next); then compound 2.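

In this assay, this position on the shared core separated the three small groups: chloro in place of methyl on an aromatic carbon gave a number 0.64 log units lower from compound 2 to compound 4 (beyond the scatter) while chloro in place of hydrogen gave a number 0.10 log units lower from compound 1 to compound 4 (within the scatter) on the same core. Chloro thus reads level with hydrogen here, and methyl alone stands apart from both. Nothing shown gives a reason for this. From the compounds shown here alone, the step from compound 3 to compound 4 cannot be read, as compound 3 has no number, and how a nitrile or a methoxy group would read at this position stays open.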